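The source may hold more compounds than are shown below. What is called first, only, known or untested is meant among the compounds shown, and "the series" means these compounds.

The measured compounds are:

compound 1, `O=[N+]([O-])c1ccc(S(=O)(=O)Nc2cnc3ccccc3c2)cc1`, 31600 nM
compound 2, `O=S(=O)(Nc1cnc2ccccc2c1)c1ccccc1`, 53400 nM
compound 3, `O=S(=O)(Oc1cccc2cccnc12)c1ccccc1`, 49500 nM

All three were tested in an assay for inhibition of beta-glucuronidase (Bos taurus), read by spectrophotometry, with a stated time of 30 min; on this read-out lower numbers stand for stronger inhibition and higher numbers for weaker inhibition. Compound 2 and compound 1 share a core and differ in one place: nitro in place of hydrogen on an aromatic carbon. This change gave a 1.7-fold lower number from compound 2 to compound 1 (0.23 log units; within the scatter). Compound 3 has a different core from compound 2; the difference between the two cores is not broken down here. In this assay compound 3 gives 49500 nM, and compound 2 gives 53400 nM, two values that lie within the scatter of each other, as does the value of compound 1.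

Compound 4, `O=[N+]([O-])c1ccccc1S(=O)(=O)Oc1cccc2cccnc12`, has not yet been measured. It differs from compound 3 in one place: nitro in place of hydrogen on an aromatic carbon. Among the compounds with values here, this is the same kind of change as the one from compound 2 to compound 1, but not the same: there the nitro group enters para to a large group, here it enters ortho to a large group.

Because the earlier change gave a 1.7-fold lower number from compound 2 to compound 1 (0.23 log units; within the scatter), a step of similar size is expected here, and the estimate means a 1.5-fold lower number from compound 3 to compound 4 (0.19 log units; within the scatter). Given that compound 3 gives 49500 nM, compound 4 is estimated at 32000 nM in this assay, with the expected range running from 12000 nM to 85000 nM. The estimate rests on a single earlier step that itself lies within the scatter, so the range is wide.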

Compound 4, half-maximal inhibitory concentration: 6400 nM
The estimate for compound 4 lay 5.0-fold (0.70 log units) above the measured number; measured number below the stated range.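

In this assay, nitro in place of hydrogen on an aromatic carbon gave a 7.7-fold lower number from compound 3 to compound 4 (0.89 log units; beyond the scatter), and this step does not match the earlier one on the other core: the same change on two cores in this assay, a 1.7-fold lower number (0.23 log units; within the scatter) from compound 2 to compound 1 and a 7.7-fold lower number (0.89 log units; beyond the scatter) from compound 3 to compound 4, 4.6-fold (0.66 log units) apart, beyond the scatter of two such steps. The size of the step therefore did not carry over from one core to the other in this series, so a step read on one core was a poor guide to the step on the second, and only the direction, a lower number on both cores, was shared. The two steps do not show what sets them apart: in compound 4 the nitro group stands ortho to a large group, while it sits elsewhere in compound 1, and the two pairs differ in core as well, so the effects of placement and core cannot be separated here.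

The compounds shown leave open whether nitro at matching places on the two cores would give steps of similar size. They also leave open whether the large step is particular to nitro or would also appear with an amine, a nitrile or a carboxylic acid at the same place on the core of compound 3.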